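This account rests on a few compounds, and the source may have more. Where it says the series, first, only, none or still open, it means among the compounds named here.

Three thiourea compounds have been tested in an assay on membranes from brain for binding affinity to Lysophosphatidylserine lipase ABHD12 (Mus musculus), read by fluorescence, with a stated time of 20 min, tested at 2 uM; a lower number here means a weaker effect, a higher number a stronger effect of the compound at the concentration tested. Compound 1 `FC(F)(F)c1cnc(N2CCC(NC(=S)Nc3cnc4ccccc4c3)CC2)c(Cl)c1` gives 0% in this assay, the lowest of the three numbers. Compound 2 `FC(F)(F)c1cnc(N2CCCC(NC(=S)Nc3cccnc3)CC2)c(Cl)c1` gives 9%, a number that lies within the usual scatter of compound 1, so the two cannot be told apart. Compound 3 `FC(F)(F)c1cnc(NCCCCCNC(=S)Nc2cccnc2)c(Cl)c1` gives 54%, and its gap to compound 1 is beyond the scatter.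

Compound 4 `FC(F)(F)c1cnc(N2CCC(NC(=S)Nc3ccccc3)CC2)c(Cl)c1` is a close relative of compound 1. The two differ in one place: phenyl in place of quinolin-3-yl on an amide-type nitrogen. Among the measured compounds shown here, no pair of measured compounds differs by exactly this change, so the expectation for compound 4 must rest on the numbers already seen. Since compound 1 gives 0% and compound 2, which carries the smaller pyridin-3-yl group in the same position, gives 9%, the step of a number 10 percentage points higher from compound 1 to compound 4 (within the scatter) is expected to stay small, likely within the scatter. Compound 4 is therefore estimated to give 10%, with a range from 0% to 35%.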

Compound 4, a percentage reported as inhibition, at one concentration (the size of the read-out at that concentration, not a potency): 66%
Compound 4: middle estimate off by 56 percentage points, on the low side; the measured number lies above the stated range.
By their numbers in this assay, from the lowest: compounds 1 and 2 (each within the scatter of the next); then compound 3; then compound 4.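

Replacing quinolin-3-yl with phenyl on the amide-type nitrogen gives, in this assay, a number 66 percentage points higher from compound 1 to compound 4 (beyond the scatter). Among the compounds shown here, this is the first comparison that changes only one place, and it shows that this single change can separate a compound with no inhibition from one with clear inhibition at the concentration tested. No measurement at hand says what lies behind this jump.

Going by these compounds, with only these two groups compared on this core, it remains open how pyridin-3-yl, or a phenyl carrying a chlorine or a methoxy group, would behave on the same nitrogen. On these data alone, it is also open whether phenyl in place of pyridin-3-yl would raise the number in the same way on the chain of compound 3 or the core of compound 2.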